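This account rests on a few compounds, and the source may have more. Where it says the series, first, only, none or still open, it means among the compounds named here.

In a functional assay on HL-60 cells (Homo sapiens) for cytotoxicity, read by MTT assay, with a stated time of 48 h (a lower number here means a stronger inhibitor, a higher number a weaker inhibitor), compound 1 `COc1ccc(Nc2nc(-c3cccc(F)c3)nc3ccc(F)cc23)cc1` gives 38600 nM. Compound 2 `Nc1cccc(Nc2nc(-c3cccc(F)c3)nc3ccc(F)cc23)c1` gives only a limit, > 50000 nM. Compound 3 `Cc1ccc(Nc2nc(-c3cccc(F)c3)nc3ccc(F)cc23)cc1` differs from compound 2 by 4-methylphenyl in place of 3-aminophenyl on a nitrogen on an aromatic ring, with 4-methylphenyl in place of 3-aminophenyl on a nitrogen on an aromatic ring. For the measured compounds named here, only one measured step bears on this change, an at least 1.2-fold higher number from compound 1 to compound 2 (0.11 log units; that floor lies within the scatter), and it runs between the same two kinds of group. The 4-methoxyphenyl of compound 1, at 38600 nM, is the closest guide to 4-methylphenyl, so a modest move to a lower number is expected. The expected change is an at least 1.4-fold lower number from compound 2 to compound 3 (0.15 log units; that floor lies within the scatter). Compound 3 is estimated at 35000 nM, within an expected range of 14000 nM to 50000 nM.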

Compound 3, half-maximal inhibitory concentration: > 50000 nM
Compound 3: a limit, no number; the forecaster's own chance of this, stated with the estimate: 35%; middle value at least 1.4-fold (0.15 log units) away from the limit.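

In this assay compound 3 gives only a limit, > 50000 nM, so 4-methylphenyl on this nitrogen yields no number, as 3-aminophenyl did. Methyl in place of methoxy on an aromatic carbon gives an at least 1.2-fold higher number from compound 1 to compound 3 (0.11 log units; that floor lies within the scatter), which leaves compound 1 as the only one of the three with a measured number. The step between the two limits cannot be read, and the limit now holds for more than one compound: the limit of > 50000 nM in this assay, at which 2 of the 3 values shown sit.

Going by these compounds, whether an ethoxy chain or a carboxylic acid in place of the methoxy of compound 1 would move the number beyond the scatter stays open.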